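The source may report more compounds than this note shows. Statements on the series, on what has been measured and on what is new or still open speak of the compounds shown alone.

Of the compounds shown here, three have been measured in an assay on U2OS cells for activation of nuclear factor erythroid 2-related factor 2 (Homo sapiens), read by beta-arrestin recruitment, with a stated time of 6 h; a higher number here means that more compound is needed for the effect, a lower number that less compound is needed. Compound 3 `O=S(=O)(/C=C/c1ccc(Cl)nc1)c1ccccc1F` gives 2550 nM, the lowest of the three numbers. Compound 1 `O=S(=O)(/C=C/c1ccc(Cl)cn1)c1ccccc1Cl` gives 2940 nM, which sits within the scatter of compound 3, while compound 2 `O=S(=O)(/C=C/c1cccnc1)c1ccccc1F` gives 6860 nM and is the furthest away. Among the compounds with values here, the one traceable step runs a 2.7-fold lower number from compound 2 to compound 3 (0.43 log units; beyond the scatter). Compound 4 `O=S(=O)(/C=C/c1ccc(Cl)nc1)c1ccccc1Cl` differs from compound 3 by chloro in place of fluoro on an aromatic carbon. Within the data shown here, no measured step shows this exchange on its own: the traced step concerns a different exchange, and compound 1 and compound 3 differ in two places, though their values lie within the scatter of each other. Expected, then, is a 1.0-fold lower number from compound 3 to compound 4 (0.01 log units; within the scatter), nothing beyond the scatter in this assay. The estimate for compound 4 is 2500 nM, ranging from 1200 nM to 5500 nM.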

Compound 4, half-maximal effective concentration: 1630 nM
Compound 4: middle estimate off by 1.5-fold (0.19 log units), on the high side; measured number inside the range.
By their numbers in this assay, from the lowest: compounds 4, 3 and 1 (each within the scatter of the next); then compound 2.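

In this assay, chloro in place of fluoro on an aromatic carbon, ortho to a large group, gives a 1.6-fold lower number from compound 3 to compound 4 (0.19 log units; within the scatter) and so stays within the scatter. Within the data shown here, this is the first view of this exchange on its own, and at this place on the ring of carbon only, the two halogens cannot be told apart in this assay. No measurement shown gives a reason for this result. As far as these compounds go, what a methyl, a methoxy or an amine at this same place would do to the number remains open.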